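Swapping Chloro for Hydroxy on Compound 1

The source may report more compounds than this note shows. Statements on the series, on what has been measured and on what is new or still open speak of the compounds shown alone.

Compound 1 `O=C1/C(=C/c2ccccc2)CCC/C1=C\c1ccc(Cl)cc1` carries a chloro group on one of its two aromatic rings. In an assay on isolated protein for inhibition of Alpha glucosidase (Homo sapiens), with stated times of 5 min and 15 min (a lower number here means a stronger inhibitor, a higher number a weaker inhibitor), compound 1 gives "not determined" (no result reported), so it stands on no single number here. A related compound, compound 2 `O=C(C1=C(O)/C(=C/c2ccc(O)c(O)c2)CCC1)c1ccccc1`, does have a value: in this assay compound 2 gives 41000 nM, which is a weak result for an inhibitor. Compound 3 `O=C1/C(=C/c2ccccc2)CCC/C1=C\c1ccc(O)cc1` differs from compound 1 in one place: hydroxy in place of chloro on an aromatic carbon. The hydroxy enters where the chloro left, on an aromatic carbon para to a large group. Within the data shown here, with no measured pair showing this change, the size of the step in this assay cannot be read from the data; a shift in either direction is possible, and none beyond the scatter would be unsurprising. Compound 3 is expected to give about 35000 nM, most likely between 8000 nM and 150000 nM.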

Compound 3, half-maximal inhibitory concentration: 42300 nM
Compound 3: the middle estimate sits 1.2-fold (0.08 log units) below what was measured, and the stated range covers the measured number.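

No step can be read between compound 1 and compound 3: in this assay compound 1 gives "not determined" (no result reported) and compound 3 gives 42300 nM as its value. Nothing shown offers an explanation for this result. The compounds shown leave open how far hydroxy in place of chloro shifts inhibition, or whether it does so at all.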